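The source may hold more compounds than are shown below. What is called first, only, known or untested is meant among the compounds shown, and "the series" means these compounds.

Measured in a functional assay on HeLa cells (Homo sapiens) for inhibition, read by sulforhodamine B assay, with a stated time of 74 h; a lower number here means a stronger inhibitor, a higher number a weaker inhibitor:
Compound 1 `Cc1ccc(S(=O)(=O)N2C(=O)COC23C=CC(=O)C=C3)cc1`: 180 nM
Compound 2 `O=C1C=CC2(C=C1)OCC(=O)N2S(=O)(=O)c1ccc([N+](=O)[O-])cc1`: > 10000 nM, a limit of the assay and not a number
Compound 3 `COc1ccc(S(=O)(=O)N2C(=O)COC23C=CC(=O)C=C3)cc1`: 880 nM

Of the two actual numbers, compound 3 holds the higher, and the gap to its nearest neighbour is a 4.9-fold higher number from compound 1 to compound 3 (0.69 log units; beyond the scatter), a modest step. Compound 4 `O=C1C=CC2(C=C1)OCC(=O)N2S(=O)(=O)c1ccc(OC(F)(F)F)cc1` changes methoxy to trifluoromethoxy: trifluoromethyl in place of methyl on an oxygen on an aromatic ring. Among the compounds with values here, no measured step makes this change on the oxygen, so the evidence is indirect. Each of the three measured steps swaps a group on an aromatic carbon. Departing from the methyl group of compound 1 raised the number both times, by a 4.9-fold higher number from compound 1 to compound 3 (0.69 log units; beyond the scatter) and, more sharply, by an at least 55-fold higher number from compound 1 to compound 2 (1.74 log units; beyond the scatter). The large step of an at least 11-fold lower number from compound 2 to compound 3 (1.05 log units; beyond the scatter) shows how far apart two such groups can fall in this assay. On that basis, a modest rise is expected, with weaker inhibition, though a step within the scatter cannot be excluded. The expected step is a 2.0-fold higher number from compound 3 to compound 4 (0.31 log units; beyond the scatter). For compound 4 the estimated value is 1800 nM, with an expected range of 400 nM to 8000 nM.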

Compound 4, half-maximal inhibitory concentration: > 10000 nM
Compound 4: only a limit was reported (the forecaster's own chance of this, stated with the estimate: 15%); middle value at least 5.5-fold (0.74 log units) from the limit.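

In this assay compound 4 gives > 10000 nM, a limit of the assay and not a number. Trifluoromethyl in place of methyl on the oxygen, the only change shown at that oxygen, gives an at least 11-fold higher number from compound 3 to compound 4 (1.05 log units; beyond the scatter), and the comparison with the methyl group on the aromatic carbon gives an at least 55-fold higher number from compound 1 to compound 4 (1.74 log units; beyond the scatter), so at this position the oxygen-bound methyl of compound 3 does not tolerate this exchange in this assay. The step between compound 2 and compound 4 cannot be read, because both values are limits: the limit of > 10000 nM in this assay, at which 2 of the 4 values shown sit.

From the compounds shown here alone, how far compound 4 lies past the limit stays unknown, so it cannot be ranked against compound 2. Going by these compounds, whether an amine, a hydroxyl or a longer alkoxy chain in the same place would keep the activity of compound 1 or compound 3 remains open.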